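Heteroaryl amide change: from compound 2 to compound 3

This account rests on a few compounds, and the source may have more. Where it says the series, first, only, none or still open, it means among the compounds named here.

In a functional assay on SNB-75 cells (Homo sapiens) for inhibition, read by colorimetric assay and sulforhodamine B assay, with a stated time of 48 h (on this read-out lower numbers stand for stronger inhibition of growth and higher numbers for weaker inhibition of growth), compound 1 (`CCCCCCCCCCCC[C@@H](O)[C@H]1CC[C@H]([C@H](O)CCCCCCCCCCNC(=O)c2cccs2)O1`) gives 3390 nM and compound 2 (`CCCCCCCCCCCC[C@@H](O)[C@H]1CC[C@H]([C@H](O)CCCCCCCCCCNC(=O)c2cncs2)O1`) gives 100000 nM as the higher of the two numbers. Compound 3 (`CCCCCCCCCCCC[C@@H](O)[C@H]1CC[C@H]([C@H](O)CCCCCCCCCCNC(=O)c2ccnn2C)O1`) differs from compound 2 by 1-methyl-1H-pyrazol-5-yl in place of 1,3-thiazol-5-yl on a carbonyl carbon with 1-methyl-1H-pyrazol-5-yl in place of 1,3-thiazol-5-yl on a carbonyl carbon. Within the data shown here, the one measured step at this place is a 29-fold higher number from compound 1 to compound 2 (1.47 log units; beyond the scatter) and it is large. A step toward lower numbers is therefore expected in this assay but smaller than that one. The expected change is a 6.7-fold lower number from compound 2 to compound 3 (0.82 log units; beyond the scatter) on this estimate. Compound 3 is estimated at 15000 nM within a range of 3000 nM to 80000 nM overall.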

Compound 3, concentration for 50% growth inhibition: 50100 nM
For compound 3 the middle estimate is 3.3-fold (0.52 log units) below the measured one; the measured number falls inside the stated range.
By their numbers in this assay, from the lowest: compound 1; then compounds 3 and 2 (each within the scatter of the next).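

In this assay, the 1-methyl-1H-pyrazol-5-yl and 1,3-thiazol-5-yl groups on the carbonyl carbon are not separated, with a 2.0-fold lower number from compound 2 to compound 3 (0.30 log units; within the scatter) between them. Against the thiophen-2-yl group the picture differs, with a 15-fold higher number from compound 1 to compound 3 (1.17 log units; beyond the scatter), so both groups containing nitrogen stand apart from compound 1 at this place. No evidence on hand accounts for this.

Still open, as far as these compounds go, is whether furan-2-yl or phenyl on the same carbonyl carbon would stay near compound 1 or fall with compound 2 and compound 3.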